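A few compounds are considered here, and "the series" means these few. Any claim that something is new, unique, unknown or untested is made for them only; others in the source may bear on it.

Measured so far:
- compound 1 `CCCC(=O)NC(c1ccc(Cl)cc1)c1cc(Cl)c2cccnc2c1O`: 120 nM
- compound 2 `O=C(NC(c1ccc(Cl)cc1Cl)c1ccc2cccnc2c1O)C1CCCC1`: 320 nM

In a functional assay on A-375 cells (Homo sapiens) for antiproliferative activity, read by trypan blue exclusion and crystal violet staining, with a stated time of 72 h (on this read-out lower numbers stand for stronger inhibition and higher numbers for weaker inhibition), compound 1 gives 120 nM. In this assay compound 2 gives 320 nM. For the measured compounds named here, compound 1 therefore carries the lower of the two numbers known so far, and its gap to compound 2 lies beyond the usual scatter. Going by the values given here, compounds 1 and 2 differ from each other in more than one place, so no single-change step between measured compounds is available, and the two values say nothing on their own about the effect of any one change.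

Compound 3 `CCCC(=O)NC(c1ccccc1)c1cc(Cl)c2cccnc2c1O` has not yet been measured. It differs from compound 1 in one place: hydrogen in place of chloro on an aromatic carbon. Among the compounds with values here, no measured pair shows this change, so the expectation rests on compound 1 alone. With hydrogen in place of chloro on an aromatic carbon, a moderate step toward a higher number in this assay is expected, that is, somewhat weaker inhibition, with a fair chance that the step stays within the scatter. For compound 3 the expected value in this assay is 300 nM, within 120 nM to 800 nM, which means an estimated step of a 2.5-fold higher number from compound 1 to compound 3 (0.40 log units; beyond the scatter).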

Compound 3, half-maximal inhibitory concentration: 130 nM
Beside the measured number, compound 3's estimate is 2.3-fold (0.36 log units) above it, and the stated range covers the measured number.
By their numbers in this assay, from the lowest: compounds 1 and 3 (each within the scatter of the next); then compound 2.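

In this assay, the series now has its first pair differing in one place, and it gives a 1.1-fold higher number from compound 1 to compound 3 (0.03 log units; within the scatter), so the change from 4-chlorophenyl to phenyl stays within the scatter. At this place, on an aromatic carbon of a six-membered aromatic ring of carbon only and para to a large group, the chloro is therefore not required for the level of inhibition seen with compound 1, at least with the rest of compound 1 kept as it is. No available measurement offers an explanation for this result.

Going by these compounds, whether other groups at this place, such as a methoxy group, an amine or a carboxylic acid, would also stay within the scatter remains open. Also open, on these data alone, are whether the chloro on the shared core can be replaced by hydrogen with a similarly small step, and whether the step from 4-chlorophenyl to phenyl reads the same when the amide carries a longer chain.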